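Pyridinone in place of pyrimidinone at the fused-ring position

The source may report more compounds than this note shows. Statements on the series, on what has been measured and on what is new or still open speak of the compounds shown alone.

Three compounds of this series have numbers in an ADME assay on cells (Hepatocyte, Rattus norvegicus) for metabolic stability; on this read-out lower numbers stand for slow clearance and higher numbers for fast clearance. Compound 1 `COc1cc(C(=O)N2CCCC2)ccc1-c1ccnc2[nH]c(C3CCOCC3)cc12` gives 15 uL/min. Compound 2 `CC(C)n1cc(-c2ccnc3[nH]c(C4CCN(CC(=O)N(C)C)CC4)cc23)cnc1=O` gives 100 uL/min, the highest of the three. Compound 3 `CC(C)n1cc(-c2ccnc3[nH]c(C4CCN(CC(=O)N5CCCCC5)CC4)cc23)ccc1=O` gives 26 uL/min. Compound 2 stands beyond the scatter from both: its number is higher than that of compound 3 by a gap beyond the scatter, and further still from compound 1. No pair among these three differs in one place only, so no single step is established.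

Compound 4 `CCn1cc(-c2ccnc3[nH]c(C4CCN(CC(=O)N(C)C)CC4)cc23)ccc1=O` is not yet measured. Its change from compound 2 is a group of 9 heavy atoms (7 carbon, 1 nitrogen, 1 oxygen; one six-membered aromatic ring with 1 hetero atom) in place of a group of 10 heavy atoms (7 carbon, 2 nitrogen, 1 oxygen; one six-membered aromatic ring with 2 hetero atoms), on an aromatic carbon. The group is placed as given: on an aromatic carbon of a six-membered aromatic ring with 1 nitrogen, part of a fused or bridged system of two rings, opposite the ring nitrogen. Compound 3 also carries a six-membered aromatic ring with 1 hetero atom at this position and gives 26 uL/min, but it differs from compound 4 elsewhere as well, so it guides only loosely. The expectation is a step downward from compound 2 to compound 4 of a 2.5-fold lower number from compound 2 to compound 4 (0.40 log units; beyond the scatter), beyond the scatter. Compound 4 is estimated at 40 uL/min, with a range of 15 uL/min to 100 uL/min.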

Compound 4, intrinsic clearance in a liver preparation (reported as CLH), per the amount of preparation that the assay uses: < 1 uL/min
Compound 4: only a limit was reported (the forecaster's own chance of this, stated with the estimate: 5%); at least 40-fold (1.60 log units) between middle value and limit.
By their numbers in this assay, from the lowest: compounds 1 and 3 (each within the scatter of the next); then compound 2. At a limit, below all of these: compound 4.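

Within the data shown here, the group on the aromatic carbon opposite the ring nitrogen carries far more weight in this assay than the earlier compounds could show: exchanging the isopropyl pyrimidinone for the ethyl pyridinone gives an at least 100-fold lower number from compound 2 to compound 4 (2.00 log units; beyond the scatter), the first step that can be read at all. On these data alone, compound 4 reads < 1 uL/min, which is a limit of the assay and not a number, so the full size of the step stays unknown: the limit of < 1 uL/min in this assay, at which 1 of the 4 values shown sits. The exchange also holds two differences at once, one ring hetero atom fewer and ethyl in place of isopropyl, so the step belongs to the two together and to neither alone.

The compounds shown do not separate the ring change from the chain change, since compound 3 combines the pyridinone with isopropyl but also differs from compound 4 in its amide. As far as these compounds go, whether a methyl or cyclopropyl group in place of the ethyl keeps the read-out at this limit remains open, as does whether the same exchange holds on the core of compound 1.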